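A Cyano Group on a Flat Aryl Series

The source may report more compounds than this note shows. Statements on the series, on what has been measured and on what is new or still open speak of the compounds shown alone.

Of the compounds shown here, three sharing one core have been measured in a functional assay on KB cells (Homo sapiens) for inhibition, with a stated time of 72 h; a higher number here means a weaker inhibitor, a lower number a stronger inhibitor. Compound 1 `COc1ccc(S(=O)(=O)N2CCc3cccc(-c4ccco4)c32)cc1`, which carries furan-2-yl, gives 82 nM. Compound 2 `COc1ccc(S(=O)(=O)N2CCc3cccc(-c4ccccc4)c32)cc1`, which carries phenyl instead, gives 120 nM. Compound 3 `COc1ccc(S(=O)(=O)N2CCc3cccc(-c4ccc(O)cc4)c32)cc1`, which carries 4-hydroxyphenyl, gives 129 nM. Compound 3 therefore stands within the scatter of both other compounds, and the three values cannot be ranked.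

The next compound is compound 4 `COc1ccc(S(=O)(=O)N2CCc3cccc(-c4ccc(C#N)cc4)c32)cc1`, which has cyano in place of hydroxy on an aromatic carbon, para to a large group: cyano in place of hydroxy on an aromatic carbon. The same difference reads as 4-hydroxyphenyl to 4-cyanophenyl.

The closest evidence is the step at this same carbon, hydroxy in place of hydrogen, which gave a 1.1-fold higher number from compound 2 to compound 3 (0.03 log units; within the scatter). Two larger replacements of the whole group gave a 1.5-fold higher number from compound 1 to compound 2 (0.17 log units; within the scatter) and a 1.6-fold higher number from compound 1 to compound 3 (0.20 log units; within the scatter). Among the measured compounds shown here, all three steps lie within the scatter, although no measured compound carries cyano, so this evidence is only indirect. No change beyond the scatter is therefore expected in this assay. The expected step is a 1.0-fold lower number from compound 3 to compound 4 (0.01 log units; within the scatter). Compound 4 is estimated at 125 nM, with an expected range of 55 nM to 300 nM.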

Compound 4, half-maximal inhibitory concentration: 31.1 nM
The estimate for compound 4 lay 4.0-fold (0.60 log units) above the measured number, and the stated range ends above it.
By their numbers in this assay, from the lowest: compound 4; then compounds 1, 2 and 3 (each within the scatter of the next).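

In this assay, among the compounds shown here, the carbon para to a large group turns out not to be indifferent to what it carries: 4-cyanophenyl is the first group to move the number beyond the scatter (a 4.1-fold lower number from compound 3 to compound 4 (0.62 log units; beyond the scatter)). The step from the unsubstituted phenyl is of nearly the same size (a 3.9-fold lower number from compound 2 to compound 4 (0.59 log units; beyond the scatter)), whereas hydroxy in place of hydrogen at this carbon changed nothing beyond the scatter (a 1.1-fold higher number from compound 2 to compound 3 (0.03 log units; within the scatter)), so the gain goes with the entry of cyano and not with the loss of hydroxy. The gap to the furan-2-yl group is also beyond the scatter, though modest (a 2.6-fold lower number from compound 1 to compound 4 (0.42 log units; beyond the scatter)), which places compound 4 alone at the low end of the series, with compounds 1, 2 and 3 unresolved from one another.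

Nothing given here accounts for the gain. The compounds shown leave open whether it belongs to cyano alone or would also appear with another group on this carbon, such as a carboxylic acid, a primary amide, an acetyl or a chlorine atom.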